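The source may hold more compounds than are shown below. What is called first, only, known or untested is meant among the compounds shown, and "the series" means these compounds.

Measured so far:
compound 1 `Cc1ccc(CNc2ncnc3c2ncn3[C@@H]2O[C@H](CO)[C@@H](O)[C@H]2O)cc1` gives > 166000 nM
compound 2 `COc1cccc(CNc2ncnc3c2ncn3[C@@H]2O[C@H](CO)[C@@H](O)[C@H]2O)c1OC` gives "not determined" (no result reported)

The value of compound 1 in an ADME assay on NIH3T3 cells (Mus musculus) for cytotoxicity, with a stated time of 72 h (a lower number here means a stronger inhibitor, a higher number a weaker inhibitor), is a limit of the assay, not a number. Compound 2 has no result in this assay. Compound 3 `COc1cccc(CNc2ncnc3c2ncn3[C@@H]2O[C@H](CO)[C@@H](O)[C@H]2O)c1O` differs from compound 2 by hydrogen in place of methyl on an oxygen on an aromatic ring. Among the measured compounds shown here, no measured step exists between these two, and in this assay no shift beyond the usual scatter is expected in either direction. For the measured compounds named here, compound 3 is estimated at 166000 nM, ranging from 50000 nM to 500000 nM, because the limit of > 166000 nM in this assay, at which 1 of the 2 values shown sits, marks where the only measured compound of the series sits.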

Compound 3, half-maximal inhibitory concentration: > 166000 nM
Compound 3 ended at the assay's limit; the forecaster's own chance of this, stated with the estimate: 80%; the middle value lies on the limit itself.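

Among the compounds shown here, compound 1 and compound 3 both stand at a limit of this assay, not at a number, so no step between them can be read. The compounds shown leave open whether 2-hydroxy-3-methoxyphenyl in place of 4-methylphenyl shifts the read-out at all.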